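Aryl amide cap change from compound 2 to compound 4

The compounds below may be only part of what the source reports. "The series", "measured", "known", "first", "only" and "open" are said of these compounds alone.

Of the compounds shown here, three have been measured: compound 1 `CN(C)c1ccc(C(=O)NC(CCCCCC(=O)NO)C(=O)NCc2ccccc2)cc1`, compound 2 `O=C(CCCCC[C@H](NC(=O)c1ccc(Br)cc1)C(=O)NCc1ccccc1)NO` and compound 3 `O=C(Cc1c[nH]c2ccccc12)C[C@@H](Cc1ccccc1)C(=O)N[C@@H](CCCCCC(=O)NO)C(=O)NCc1ccccc1`. In a functional assay on NFF cells (Homo sapiens) for antiproliferative activity (a higher number here means a weaker inhibitor, a lower number a stronger inhibitor), compound 1 gives 870 nM, compound 2 gives 5860 nM and compound 3 gives 9800 nM. Compound 2 stands second highest of the three numbers; its number and that of compound 3 lie within the usual scatter of each other, whereas compound 1 sits clearly lower, beyond the scatter. Compound 4 `O=C(CCCCC[C@H](NC(=O)c1cc2c(O)cccc2[nH]1)C(=O)NCc1ccccc1)NO` is not yet measured. It differs from compound 2 in one place: 4-hydroxy-1H-indol-2-yl in place of 4-bromophenyl on a carbonyl carbon. Among the compounds with values here, no measured pair covers this kind of change, so the expectation rests on little. In this assay the expected step is a 2.3-fold lower number from compound 2 to compound 4 (0.37 log units; beyond the scatter), toward a lower number, of a size that may not clear the scatter. Compound 4 is estimated at 2500 nM, with a range from 800 nM to 8000 nM.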

Compound 4, half-maximal inhibitory concentration: 2210 nM
Compound 4: the middle estimate sits 1.1-fold (0.05 log units) above what was measured; the measured number falls inside the stated range.
By their numbers in this assay, from the lowest: compound 1; then compound 4; then compounds 2 and 3 (each within the scatter of the next).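

In this assay, the group on the carbonyl carbon of the amide cap now has its first single-place comparison: 4-hydroxy-1H-indol-2-yl in place of 4-bromophenyl gives a 2.7-fold lower number from compound 2 to compound 4 (0.42 log units; beyond the scatter), a modest step beyond the scatter. The entering group adds a five-membered aromatic ring and hydrogen-bond donors and loses the bromine, so these changes cannot be separated here. Nothing available explains the step.

From the compounds shown here alone, whether the hydroxyl or the added ring carries the step stays open. A plain 1H-indol-2-yl at this place would separate the two.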